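This account rests on a few compounds, and the source may have more. Where it says the series, first, only, none or still open, it means among the compounds named here.

- compound 1 `Cc1ccc(NS(=O)(=O)c2ccc(N3CCNC3=O)cc2)cc1` at 480 nM
- compound 2 `Cc1cc(C)cc(NS(=O)(=O)c2ccc(N3CCNC3=O)cc2)c1` at 82 nM

Within the data shown here, in a functional assay on HT-29 cells (Homo sapiens) for antiproliferative activity, read by sulforhodamine B assay, with a stated time of 48 h (on this read-out higher numbers stand for weaker inhibition and lower numbers for stronger inhibition), compound 2 has the lower of the two numbers so far, which makes it the stronger inhibitor of this pair. The next structure, compound 3 `Cc1cccc(NS(=O)(=O)c2ccc(N3CCNC3=O)cc2)c1C`, has 2,3-dimethylphenyl in place of 3,5-dimethylphenyl on a sulfonamide nitrogen. The two structures have the same atoms, joined differently.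

Among the measured compounds shown here, only one measured step bears on this change: a 5.9-fold lower number from compound 1 to compound 2 (0.77 log units; beyond the scatter). It also altered the group on the sulfonamide nitrogen, and it shows that a change there can move the number beyond the scatter. For the measured compounds named here, it cannot show what this particular rearrangement will do, as no measured compound carries the 2,3-dimethylphenyl group. Going by the values given here, with compound 2 at the low end of the numbers so far (82 nM), a rise looks more likely than a further fall, and it is expected to be no larger than the measured step. The expected change is a 2.2-fold higher number from compound 2 to compound 3 (0.34 log units; beyond the scatter). For compound 3 the estimated value is 180 nM, with an expected range from 50 nM to 600 nM.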

Compound 3, half-maximal inhibitory concentration: 190 nM
For compound 3 the middle estimate is 1.1-fold (0.02 log units) below the measured one; the measured number falls inside the stated range.
By their numbers in this assay, from the lowest: compound 2; then compound 3; then compound 1.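

Rearranging the same atoms on the ring matters in this assay: the change to 2,3-dimethylphenyl gives a 2.3-fold higher number from compound 2 to compound 3 (0.36 log units; beyond the scatter) and so shows that the positions of the methyl groups count, not only their presence. Compound 3 also stands apart from the single-methyl compound, with a 2.5-fold lower number from compound 1 to compound 3 (0.40 log units; beyond the scatter) on the move from 4-methylphenyl to 2,3-dimethylphenyl. Among these three compounds, both dimethylphenyl groups therefore give lower numbers than 4-methylphenyl, but 2,3-dimethylphenyl keeps less of that advantage than 3,5-dimethylphenyl, and no supporting measurement is available to explain the difference between these arrangements.

The compounds shown leave open how other arrangements of the same groups, such as 2,6-dimethylphenyl or 3,4-dimethylphenyl, would compare with 3,5-dimethylphenyl. They also leave open whether the ranking seen with methyl groups would hold for other groups on the ring, such as chlorine, methoxy or a carboxylic acid.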